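Urea to amide on a chlorinated anilide

A few compounds are considered here, and "the series" means these few. Any claim that something is new, unique, unknown or untested is made for them only; others in the source may bear on it.

Compound 1 `O=C(NCCCCl)Nc1ccc(I)cc1` stands at the edge of what the assay reports. In a functional assay on M21 cells (Homo sapiens) for antiproliferative activity, with a stated time of 48 h (a lower number here means a stronger inhibitor, a higher number a weaker inhibitor), compound 1 gives > 100000 nM, which is a limit of the assay and not a measured number. For the measured compounds named here, compound 2 `CC(C)(C)c1ccc(NC(=O)NCCCCl)cc1` is the only other compound with a value: in this assay compound 2 gives 35000 nM. Going by the values given here, the single measured step, an at least 2.8-fold lower number from compound 1 to compound 2 (0.45 log units; beyond the scatter), is shaped by the limit of > 100000 nM in this assay, at which 1 of the 2 values shown sits, and concerns the aromatic substituent, not the part of the molecule that changes next.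

Compound 3 `O=C(CCCl)Nc1ccc(I)cc1` differs from compound 1 in that (2-chloroethyl in place of (3-chloropropyl)amino on a carbonyl carbon). Among the compounds with values here, no measured step touches this position, so nothing in the data points to a direction for the change. The step is expected to be modest at most: a number no higher from compound 1 to compound 3 (the limit leaves the size open). Compound 3 is therefore estimated at about 100000 nM, with a range from 30000 nM to 300000 nM.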

Compound 3, half-maximal inhibitory concentration: 20000 nM
For compound 3 the middle estimate is 5.0-fold (0.70 log units) above the measured one; measured number outside the range, below it.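

In this assay, 2-chloroethyl in place of (3-chloropropyl)amino on the carbonyl carbon gives an at least 5.0-fold lower number from compound 1 to compound 3 (0.69 log units; beyond the scatter). For the compounds shown here, this is the first measured step at this position, and it shows that the number responds to a change on the carbonyl carbon as well as to the aromatic substituent changed in the earlier step. The change removes a hydrogen-bond donor and shortens the group by two heavy atoms together, and the true size of the step remains open: the limit of > 100000 nM in this assay, at which 1 of the 3 values shown sits.

The compounds shown do not tell whether the nitrogen or the chain length accounts for the step, which a 3-chloropropyl group on the same carbonyl carbon would help to separate. They also leave open whether the chlorine matters, as no chain here ends in an amine or a hydroxyl group, and whether tert-butyl would give a lower number on the amide too.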